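This account rests on a few compounds, and the source may have more. Where it says the series, first, only, none or still open, it means among the compounds named here.

Of the compounds shown here, three sharing one core have been measured in a functional assay on MGC-803 cells (Homo sapiens) for inhibition, read by CCK-8 assay, with a stated time of 48 h; a higher number here means a weaker inhibitor, a lower number a stronger inhibitor. Compound 1 (`CCN1CCN(C(=S)SCC(=O)N(Cc2ccc(OC)cc2)c2cc(OC)c(OC)c(OC)c2)CC1`) gives 9890 nM, compound 2 (`COc1ccc(CN(C(=O)CSC(=S)N2CCc3ccccc32)c2cc(OC)c(OC)c(OC)c2)cc1`) gives 8410 nM, and compound 3 (`COc1cc(N(Cc2ccc(Br)cc2)C(=O)CSC(=S)N2CCN(C(=O)OC(C)(C)C)CC2)cc(OC)c1OC`) gives 12400 nM. Compound 3 has the highest number of the three, but its gaps to compound 1 and compound 2 both lie within the usual scatter, so the three cannot be ranked. Compound 4 (`COc1ccc(CN(C(=O)CSC(=S)N2CCN(C(=O)OC(C)(C)C)CC2)c2cc(OC)c(OC)c(OC)c2)cc1N=[N+]=[N-]`) keeps the rest of compound 3 and changes one group: 3-azido-4-methoxyphenyl in place of 4-bromophenyl on a saturated chain carbon bound to an amide-type nitrogen. In words, 3-azido-4-methoxyphenyl takes the place of 4-bromophenyl on a saturated chain carbon bound to an amide-type nitrogen.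

Within the data shown here, only one measured step isolates a single change, a 1.2-fold lower number from compound 1 to compound 2 (0.07 log units; within the scatter), and it concerns the group on a thiocarbonyl carbon, not the place that changes here. Among the measured compounds shown here, no measured step shows this exchange alone, so the data give only indirect guidance. For the measured compounds named here, the one step available stayed within the scatter, and all three values in this assay sit close together. No step beyond the scatter is therefore expected, and any shift would be a modest one towards a lower number. The expected change is a 1.6-fold lower number from compound 3 to compound 4 (0.19 log units; within the scatter). For compound 4 the estimated value is 8000 nM, with an expected range of 2000 nM to 22000 nM.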

Compound 4, half-maximal inhibitory concentration: 810 nM
Compound 4: the middle estimate sits 9.9-fold (0.99 log units) above what was measured; measured number outside the range, below it.
By their numbers in this assay, from the lowest: compound 4; then compounds 2, 1 and 3 (each within the scatter of the next).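

In this assay, among these compounds, the benzyl-type position on the amide-type nitrogen proves sensitive: 3-azido-4-methoxyphenyl in place of 4-bromophenyl gives a 15-fold lower number from compound 3 to compound 4 (1.18 log units; beyond the scatter), whereas the one earlier step, at the thiocarbonyl carbon, gave only a 1.2-fold lower number from compound 1 to compound 2 (0.07 log units; within the scatter). The exchange removes the bromine and brings in an azido and a methoxy group together, raising the substituent from 7 to 11 heavy atoms and from 0 to 2 hydrogen-bond acceptors, so this single step cannot assign the gain to any one of these differences. Nothing available here bears on why this exchange lowers the number so strongly.

The compounds shown leave open whether the azido group, the methoxy group or only the pair of them accounts for the step, a question that 3-azidophenyl and 4-methoxyphenyl on the core of compound 3 would separate. They also leave open whether the azido group itself is needed or whether an amine or a nitrile in its place would give a similarly low number in this assay.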